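Removing the nitro group in a series of inactive anilinoquinazolines

A few compounds are considered here, and "the series" means these few. Any claim that something is new, unique, unknown or untested is made for them only; others in the source may bear on it.

Compound 1, `O=[N+]([O-])c1ccc(COc2ccc(Nc3ncnc4cc5c(cc34)OCCOCCO5)cc2)cc1`: in a functional assay on DU-145 cells (Homo sapiens) for antiproliferative activity, read by MTT assay, with a stated time of 72 h (on this read-out higher numbers stand for weaker inhibition and lower numbers for stronger inhibition), compound 1 gives > 100000 nM, a limit of the assay.
Compound 2, `c1ccc(COc2ccc(Nc3ncnc4cc5c(cc34)OCCOCCO5)cc2)cc1`: compound 2 gives > 100000 nM, also a limit of the assay.
Compound 3, `O=[N+]([O-])c1ccc(COc2cccc(Nc3ncnc4cc5c(cc34)OCCOCCO5)c2)cc1`: compound 3 gives > 100000 nM, again a limit of the assay.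

The change from compound 1 to compound 2 is hydrogen in place of nitro on an aromatic carbon. Its step, a step that the two limits leave unreadable from compound 1 to compound 2, cannot be sized, since both values are limits; all three measured values sit at the limit of > 100000 nM in this assay, at which 3 of the 3 values shown sit. Compound 3 has the same atoms as compound 1, joined differently, and the difference between the two cores is not broken down here.

Compound 4, `c1ccc(COc2cccc(Nc3ncnc4cc5c(cc34)OCCOCCO5)c2)cc1`, is not yet measured. Among the measured compounds shown here, it differs from compound 3 by hydrogen in place of nitro on an aromatic carbon, the same change, at the same kind of place, as the one from compound 1 to compound 2. With the earlier step unreadable, the expected step that the limit leaves unreadable from compound 3 to compound 4 rests on every measured compound staying at the limit. Compound 4 is therefore expected to give 150000 nM in this assay, most likely reported only as a limit.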

Compound 4, half-maximal inhibitory concentration: > 100000 nM
Compound 4 ended at the assay's limit; the forecaster's own chance of this, stated with the estimate: 85%; the middle value lies beyond the limit too.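

Compound 3 and compound 4 both stay at the limit, so no size can be given for the change from nitro to hydrogen in this pair, just as for compound 1 and compound 2: the limit of > 100000 nM in this assay, at which 4 of the 4 values shown sit.

The compounds shown leave open whether hydrogen in place of nitro changes activity at all: none of them yields an actual number to compare.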